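A few compounds are considered here, and "the series" means these few. Any claim that something is new, unique, unknown or untested is made for them only; others in the source may bear on it.

Working notes on the series in an ADME assay for permeability, using PAMPA, with a stated time of 30 min, at pH 7.4; on this read-out higher numbers stand for higher permeability and lower numbers for lower permeability.

Of the compounds shown here, three have numbers so far. Compound 1 `COc1ccccc1Oc1ccc2c(NCCCNCc3ccco3)ccnc2c1` gives 317 10^-6 cm/s. Compound 2 `c1ccc(Oc2ccc3c(NCCCNCc4ccco4)ccnc3c2)cc1` gives 317 10^-6 cm/s. Compound 3 `FC(F)(F)c1ccc(-c2ccc3c(NCCCNCc4ccco4)ccnc3c2)cc1` gives 237 10^-6 cm/s; of the three numbers this is the lowest, but the gap to compound 1 and to compound 2 is in each case within the scatter, so the three compounds cannot be separated on this read-out.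

The steps confirm this: no change at the digits printed from compound 1 to compound 2 (within the scatter); a 1.3-fold lower number from compound 1 to compound 3 (0.13 log units; within the scatter); a 1.3-fold lower number from compound 2 to compound 3 (0.13 log units; within the scatter). Two of these steps already exchange the whole group on the same aromatic carbon of the shared core, and neither moved the number beyond the scatter.

Compound 4 `c1coc(CNCCCNc2ccnc3cc(-c4cccc5ccccc45)ccc23)c1` is the next member. It differs from compound 3 as follows: naphthalen-1-yl in place of 4-(trifluoromethyl)phenyl on an aromatic carbon. The change again replaces the entire group on that aromatic carbon, with no donor or acceptor added or removed, so the steps from compound 1 and from compound 2 to compound 3 are the ones that bear on it, and both were within the scatter.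

Compound 4 is therefore expected to stay close to compound 3, with a step of a 1.1-fold higher number from compound 3 to compound 4 (0.02 log units; within the scatter). The estimate for compound 4 is 250 10^-6 cm/s, with a range from 140 10^-6 cm/s to 420 10^-6 cm/s.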

Compound 4, apparent permeability: 237 10^-6 cm/s
Estimate against measurement, compound 4: 1.1-fold (0.02 log units) above; the measured number falls inside the stated range.
By their numbers in this assay, from the lowest: compounds 3, 4, 1 and 2 (each within the scatter of the next).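

The exchange of 4-(trifluoromethyl)phenyl for naphthalen-1-yl, with 10 heavy atoms on each side but one six-membered aromatic ring leaving and 2 entering, gives no change at the digits printed from compound 3 to compound 4 (within the scatter) in this assay. Set against the two oxygen-linked groups, naphthalen-1-yl gives a 1.3-fold lower number from compound 2 to compound 4 (0.13 log units; within the scatter) when it replaces phenoxy and a 1.3-fold lower number from compound 1 to compound 4 (0.13 log units; within the scatter) when it replaces 2-methoxyphenoxy, so all four groups on this aromatic carbon now lie within the scatter of one another and none can be separated from the rest on this read-out. Nothing available gives a reason for this flat picture.

Every group shown on this aromatic carbon carries at least one six-membered aromatic ring, so it stays open whether an amine, a carboxylic acid or a short alkyl group there would also leave the number within the scatter. The four compounds also share the same side chain on the core, which leaves open what a longer chain in its place would do to the number in this assay.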